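A few compounds are considered here, and "the series" means these few. Any claim that something is new, unique, unknown or untested is made for them only; others in the source may bear on it.

Measured compounds in a functional assay on MDA-MB-231 cells (Homo sapiens) for cytotoxicity, read by MTT assay; a higher number here means a weaker inhibitor, a lower number a stronger inhibitor:
compound 1 `COc1ccc(/C=C2\CCC/C(=C\c3cccc([N+](=O)[O-])c3)C2=O)cc1` gives 44.7 ug/mL
compound 2 `COc1cccc(/C=C2\CCC/C(=C\c3cccc([N+](=O)[O-])c3)C2=O)c1` gives 13.2 ug/mL
compound 3 `O=C1/C(=C/c2ccc([N+](=O)[O-])cc2)CCC/C1=C\c1cccc([N+](=O)[O-])c1` gives 8.85 ug/mL

Compound 3 holds the lowest number of the three in this assay. Its nearest neighbour is compound 2, at a gap of a 1.5-fold lower number from compound 2 to compound 3 (0.17 log units; within the scatter); its furthest is compound 1, at a gap of a 5.1-fold lower number from compound 1 to compound 3 (0.70 log units; beyond the scatter).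

Compound 4 `COc1cccc(/C=C2\CCC/C(=C\c3ccc([N+](=O)[O-])cc3)C2=O)c1` follows from compound 3 by methoxy in place of nitro on an aromatic carbon, the position being on an aromatic carbon of a six-membered aromatic ring of carbon only, meta to a large group.

Among the measured compounds shown here, two measured steps bear on this change. The swap of nitro for methoxy is seen in reverse in a 5.1-fold lower number from compound 1 to compound 3 (0.70 log units; beyond the scatter), which on its own would point to a higher number for compound 4. Against that, the comparison of a methoxyphenyl arm with a nitrophenyl arm in a 1.5-fold lower number from compound 2 to compound 3 (0.17 log units; within the scatter) shows no difference beyond the scatter. A small to modest rise in this assay is therefore expected, rather than a large one.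

Compound 4 is estimated at 16 ug/mL, within a range of 7 ug/mL to 36 ug/mL, an expected step of a 1.8-fold higher number from compound 3 to compound 4 (0.26 log units; within the scatter).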

Compound 4, half-maximal inhibitory concentration: 51.4 ug/mL
The estimate for compound 4 lay 3.2-fold (0.51 log units) below the measured number, outside the stated range (above it).
By their numbers in this assay, from the lowest: compounds 3 and 2 (each within the scatter of the next); then compounds 1 and 4 (each within the scatter of the next).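

In this assay, the change from 3-nitrophenyl to 3-methoxyphenyl gives a 5.8-fold higher number from compound 3 to compound 4 (0.76 log units; beyond the scatter), so the swap of methoxy for nitro at this position, meta to a large group, registers beyond the scatter. Together with a 5.1-fold lower number from compound 1 to compound 3 (0.70 log units; beyond the scatter), that makes two single swaps in which the nitro compound carries the lower number, while a 1.5-fold lower number from compound 2 to compound 3 (0.17 log units; within the scatter) goes against any general rule, since that exchange of arms stays within the scatter. No measurement at hand explains the size of the new step.

Going by these compounds, whether the rise follows from gaining methoxy or from losing nitro remains open. An amine, a chlorine or a plain hydrogen on this aromatic carbon would help separate the two readings.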